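A few compounds are considered here, and "the series" means these few. Any claim that something is new, unique, unknown or untested is made for them only; others in the source may bear on it.

Measured so far:
Compound 1, `C[C@@H]1CN(c2ncccc2C(F)(F)F)CCN1C(=O)Nc1ccc(C(F)(F)F)cc1`: 17 nM
Compound 2, `Cc1cccnc1-c1ccc(C(=O)Nc2ccc(C(C)C)cc2)cc1`: 73 nM

In a functional assay for antagonist activity at transient receptor potential cation channel subfamily V member 1 (Homo sapiens), read by FLIPR (on this read-out lower numbers stand for stronger inhibition and higher numbers for weaker inhibition), compound 2 gives 73 nM, the higher of the two numbers; compound 1 gives 17 nM, and that gap lies beyond the usual scatter. Compound 3, `Cc1cccnc1-c1ccc(C(=O)Nc2ccc(F)cc2)cc1`, has not been measured yet. It differs from compound 2 by fluoro in place of isopropyl on an aromatic carbon. Going by the values given here, no pair of measured compounds shows a change of this kind, so nothing here calibrates it directly. The step from compound 2 to compound 3 is expected to move toward weaker inhibition, by roughly a 5.5-fold higher number from compound 2 to compound 3 (0.74 log units; beyond the scatter). Compound 3 is accordingly estimated at 400 nM, with a likely range from 100 nM to 2000 nM.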

Compound 3, half-maximal inhibitory concentration: > 4000 nM
Compound 3 ended at the assay's limit; the forecaster's own chance of this, stated with the estimate: 10%; middle value at least 10-fold (1.00 log units) away from the limit.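

In this assay compound 3 gives > 4000 nM, which is a limit of the assay and not a number. Putting fluoro in place of isopropyl on this aromatic carbon, para to a large group, gives an at least 54-fold higher number from compound 2 to compound 3 (1.73 log units; beyond the scatter), so this single change is enough to take the inhibition of compound 2 down to that limit. Going by these compounds alone, this is the first one-place comparison, and it shows that the group at this position matters greatly.

The compounds shown leave open how inhibition would respond to a methyl, an ethyl, a chlorine or a tert-butyl group at this position. They also cannot tell how far beyond the limit compound 3 really lies.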